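Methoxy in place of methyl on a short-lived compound

The source may hold more compounds than are shown below. What is called first, only, known or untested is meant among the compounds shown, and "the series" means these compounds.

compound 1 `COc1ccc2c(c1)C(=O)C(CN(C)C)CC2`: 6.8 h
compound 2 `Cc1cc(C)c2c(c1)C(=O)C(CN(C)C)CC2`: 14.4 h
compound 3 `Cc1ccc2c(c1)CC(CN(C)C)C2=O`: 0.4 h

All three compounds were measured in a physicochemical assay for pharmacokinetics, read by HPLC, at pH 7.5, tested at 250 uM; on this read-out lower numbers stand for a shorter-lived compound and higher numbers for a longer-lived compound. Compound 3 gives the lowest number of the three, at 0.4 h, and its gaps to compound 1 and to compound 2 both lie beyond the scatter. Among the measured compounds shown here, compound 3 is also the only measured compound on its core, since compound 1 and compound 2 share a different one.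

Compound 4 `COc1ccc2c(c1)CC(CN(C)C)C2=O` keeps the core of compound 3 and carries methoxy in place of methyl on an aromatic carbon. For the measured compounds named here, no measured pair shows this exchange on its own. Compound 1 does carry a methoxy group, but it differs from compound 3 in more than one place, so its value cannot be read as the effect of the exchange.

The expectation in this assay therefore stays close to compound 3 at 0.4 h, with no step beyond the scatter and no firm direction. The estimated step, a 1.3-fold higher number from compound 3 to compound 4 (0.10 log units; within the scatter), is small. The expected half-life of compound 4 is 0.5 h, with an estimated range from 0.25 h to 1 h.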

Compound 4, half-life: 0.75 h
Compound 4: middle estimate off by 1.5-fold (0.18 log units), on the low side; the measured number falls inside the stated range.
By their numbers in this assay, from the lowest: compounds 3 and 4 (each within the scatter of the next); then compound 1; then compound 2.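

In this assay, among the compounds shown here, the exchange of methyl for methoxy on this aromatic carbon gives a 1.9-fold higher number from compound 3 to compound 4 (0.27 log units; within the scatter) and provides the first measured step between compounds that differ in one place. On the core of compound 3, this position therefore accepts methoxy in place of methyl, with its added oxygen and hydrogen-bond acceptor, without a half-life that can be told apart from that of compound 3. No measurement shown here bears on why the two compounds sit so close, and no explanation can be offered from these data.

The compounds shown leave open whether a different group on this aromatic carbon, such as an amine, a carboxylic acid or a longer alkoxy chain, would move the half-life on this core beyond the scatter. They also leave open whether methoxy in place of methyl would behave in the same way on the core of compound 1, since no compound shown differs from compound 1 by that single exchange.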